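A few compounds are considered here, and "the series" means these few. Any claim that something is new, unique, unknown or untested is made for them only; others in the source may bear on it.

The measured compounds are:

compound 1, `O=C1C(Nc2ccc(F)cc2)=CC(=O)c2ncncc21`, which in a functional assay on SK-MEL-2 cells (Homo sapiens) for cytotoxicity, read by MTT assay, with a stated time of 72 h (on this read-out lower numbers stand for stronger inhibition and higher numbers for weaker inhibition), gives 0.05 ug/mL;
compound 2, `O=C1C(Nc2ccccc2)=CC(=O)c2ncncc21`, which in this assay gives 0.01 ug/mL;
compound 3, `O=C1C(Nc2ccc(Br)cc2)=CC(=O)c2ncncc21`, which in this assay gives 0.02 ug/mL.

Among these three numbers compound 3 holds the second highest. Its nearest neighbour is compound 2, and that separation, a 2.0-fold higher number from compound 2 to compound 3 (0.30 log units; within the scatter), is within the scatter. Its furthest neighbour is compound 1, and that separation, a 2.5-fold lower number from compound 1 to compound 3 (0.40 log units; beyond the scatter), is beyond the scatter but still modest.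

Compound 4, `Cc1ccc(NC2=CC(=O)c3ncncc3C2=O)cc1`, has not yet been measured. It differs from compound 3 in one place: methyl in place of bromo on an aromatic carbon.

Among the compounds with values here, two measured steps bear on this change. Both alter the same aromatic carbon. The step of a 2.5-fold lower number from compound 1 to compound 3 (0.40 log units; beyond the scatter) and the step of a 2.0-fold higher number from compound 2 to compound 3 (0.30 log units; within the scatter) show that exchanging the group at this carbon among fluoro, hydrogen and bromo moved the numbers only modestly, and in one case not beyond the scatter. The widest movement seen at this carbon is a 5.0-fold lower number from compound 1 to compound 2 (0.70 log units; beyond the scatter). A methyl at the same carbon is therefore expected to leave the number close to that of compound 3, with no step beyond the scatter being the most likely outcome in this assay.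

On that basis compound 4 is estimated at 0.02 ug/mL, with a range from 0.008 ug/mL to 0.06 ug/mL, which is expected to amount to no change at the digits printed from compound 3 to compound 4 (within the scatter).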

Compound 4, half-maximal inhibitory concentration: 0.02 ug/mL
Compound 4: middle estimate and measured number agree at the digits printed; the measured number falls inside the stated range.
By their numbers in this assay, from the lowest: compounds 2, 3 and 4 (each within the scatter of the next); then compound 1.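

In this assay, methyl in place of bromo on this aromatic carbon, para to a large group, gives no change at the digits printed from compound 3 to compound 4 (within the scatter) and adds a carbon substituent to the halogens and hydrogen already compared at this position. Methyl in place of hydrogen gives a 2.0-fold higher number from compound 2 to compound 4 (0.30 log units; within the scatter) and methyl in place of fluoro gives a 2.5-fold lower number from compound 1 to compound 4 (0.40 log units; beyond the scatter), so compounds 2, 3 and 4 lie within the scatter of one another, while compound 1 is the only compound whose steps to all the others are beyond the scatter. No measurement offered here explains why methyl, bromo and hydrogen give such similar numbers or why fluoro stands apart.

The compounds shown leave open whether this position accepts groups of a different kind or larger size, such as an amine, a carboxylic acid or a longer chain like butyl, with numbers that stay close to those of compounds 2, 3 and 4. They also leave open whether fluoro is alone in standing apart, and a chloro group at the same carbon would bear directly on that question.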